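The source may hold more compounds than are shown below. What is called first, only, known or untested is meant among the compounds shown, and "the series" means these compounds.

Of the compounds shown here, three sharing one core have been measured in a functional assay on A549 cells (Homo sapiens) for antiproliferative activity, read by MTT assay, with a stated time of 48 h; on this read-out higher numbers stand for weaker inhibition and lower numbers for stronger inhibition. Compound 1 (`CC(=O)OC/C1=C/C[C@](C)(CCC=C(C)C)/C=C/[C@@H](OC(=O)C=C(C)C)[C@](C)(OC(C)=O)/C=C/C1=O`) gives 15100 nM, compound 2 (`COC/C1=C/C[C@](C)(CCC=C(C)C)/C=C/[C@@H](OC(=O)C=C(C)C)[C@](C)(O)/C=C/C1=O`) gives 3950 nM and compound 3 (`CC(=O)O[C@]1(C)/C=C/C(=O)/C(CO)=C\C[C@](C)(CCC=C(C)C)/C=C/[C@H]1OC(=O)C=C(C)C`) gives 3150 nM. The values for compound 2 and compound 3 lie within the scatter of each other, while the number for compound 1 is higher than both, beyond the scatter.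

The next compound, compound 4 (`CC(C)=CCC[C@]1(C)/C=C/[C@@H](OC(=O)C=C(C)C)[C@](C)(O)/C=C/C(=O)/C(CN2CCCC2)=C\C1`), keeps the rest of compound 2 but carries pyrrolidin-1-yl in place of methoxy on a saturated chain carbon bound to a double-bonded ring carbon.

Among the compounds with values here, only one measured step changes a group at this place: a 4.8-fold lower number from compound 1 to compound 3 (0.68 log units; beyond the scatter). Within the data shown here, there, hydrogen replaces acetyl on an oxygen, and that modest step is the only guide to size. Among the measured compounds shown here, no measured compound has a nitrogen or a ring at this place, so the data give no firm direction. A modest step at most is therefore expected in this assay, in either direction. The estimated step is small, a 1.3-fold lower number from compound 2 to compound 4 (0.12 log units; within the scatter), and it may well stay within the scatter. For compound 4 the estimated value is 3000 nM, with an expected range from 800 nM to 11000 nM.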

Compound 4, half-maximal inhibitory concentration: 180 nM
Compound 4: middle estimate off by 17-fold (1.22 log units), on the high side; the measured number lies below the stated range.
By their numbers in this assay, from the lowest: compound 4; then compounds 3 and 2 (each within the scatter of the next); then compound 1.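

In this assay, putting pyrrolidin-1-yl in place of methoxy on a saturated chain carbon bound to a double-bonded ring carbon gives a 22-fold lower number from compound 2 to compound 4 (1.34 log units; beyond the scatter) as a large step, well beyond the modest 4.8-fold lower number from compound 1 to compound 3 (0.68 log units; beyond the scatter) seen earlier at this place. The earlier compounds shown here carry only oxygen-linked groups here, so they gave no sign that this place could move the number so far; the entering group brings a nitrogen and a five-membered non-aromatic ring, and with them the number falls steeply. No measurement here accounts for the size of this step.

The nitrogen and the ring enter together, so the compounds shown cannot tell which of them matters, or whether both do; an open-chain amine such as dimethylamino at this place would begin to separate the two. On these data alone, it also remains open how far the ring itself can be varied, for example by a piperidin-1-yl or morpholin-4-yl group, and whether such groups would keep a number as low as that of compound 4 at 180 nM.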